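Fluorine count on the benzyl group and cytotoxicity

A few compounds are considered here, and "the series" means these few. Any claim that something is new, unique, unknown or untested is made for them only; others in the source may bear on it.

Compound 3 `CCOC(=O)/C(O)=C/C(=O)c1cn(Cc2ccc(F)c(F)c2F)c2cccc(OC)c12` was examined in an ADME assay on MT4 cells (Homo sapiens) for cytotoxicity, read by MTT assay (on this read-out lower numbers stand for higher toxicity in this test and higher numbers for lower toxicity in this test), where compound 3 gives 42700 nM. Two related compounds carry the same core. Compound 1 `COc1cccc2c1c(C(=O)/C=C(\O)C(=O)O)cn2Cc1ccccc1F` gives 70500 nM in this assay, and compound 2 `COc1cccc2c1c(C(=O)/C=C(\O)C(=O)O)cn2Cc1c(F)cccc1F` gives 44300 nM. The three values lie within the usual scatter of one another, so compound 3 cannot be set apart from compound 1 or compound 2 on these numbers. Among the compounds with values here, the single measured step between neighbours, a 1.6-fold lower number from compound 1 to compound 2 (0.20 log units; within the scatter), places a fluorine where a hydrogen stood on the ring of the benzyl group and leaves the read-out unchanged beyond the scatter.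

Compound 4 `CCOC(=O)/C(O)=C/C(=O)c1cn(Cc2cc(F)ccc2F)c2cccc(OC)c12` has not yet been measured. It differs from compound 3 in one place: 2,5-difluorophenyl in place of 2,3,4-trifluorophenyl on a saturated chain carbon bound to an aromatic nitrogen. The change again concerns only the fluorines on that ring. Within the data shown here, the only step that bears on it, a 1.6-fold lower number from compound 1 to compound 2 (0.20 log units; within the scatter), was within the scatter, and nothing among the measured compounds points to a larger effect when a fluorine is removed rather than added. Compound 4 is therefore expected to give about 45000 nM in this assay, with a range from 22000 nM to 90000 nM. The expected step, a 1.1-fold higher number from compound 3 to compound 4 (0.02 log units; within the scatter), is estimated to stay within the scatter.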

Compound 4, half-maximal cytotoxic concentration: 41200 nM
The estimate for compound 4 lay 1.1-fold (0.04 log units) above the measured number; measured number inside the range.
By their numbers in this assay, from the lowest: compounds 4, 3, 2 and 1 (each within the scatter of the next).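

In this assay, the step of a 1.0-fold lower number from compound 3 to compound 4 (0.02 log units; within the scatter) is the first one shown among compounds carrying the ethyl ester, whereas the earlier step belonged to compounds carrying the free carboxylic acid. Within the data shown here, it is also the first change at this position that lowers the fluorine count and moves the fluorines around the ring at the same time, and it stays within the scatter, as the single added fluorine did. Across the fluorinated benzyl groups shown, neither the number of fluorines nor their arrangement separates these compounds on this read-out, though the change combines the two and cannot apportion anything between them, and nothing available explains why the read-out stays level.

All the benzyl groups shown carry only fluorine on the ring, so it remains open whether a benzyl group with chlorine or an amine on that ring, or a longer chain on the aromatic nitrogen in its place, would stay within the same scatter. From the compounds shown here alone, it also remains open how the ethyl ester and the carboxylic acid compare when they carry the same benzyl group.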